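This account rests on a few compounds, and the source may have more. Where it says the series, first, only, none or still open, it means among the compounds named here.

Measured compounds:
Compound 1, `CCCCCCCCCCCCCCCCNC(=O)[C@H](O)CO[C@H]1O[C@H](CO)[C@@H](O)[C@H](O)[C@H]1NC(C)=O`: in a functional assay on A549 cells (Homo sapiens) for cytotoxicity, read by sulforhodamine B assay, with a stated time of 72 h (on this read-out lower numbers stand for stronger inhibition and higher numbers for weaker inhibition), compound 1 gives > 10000 nM, a limit of the assay rather than a number.
Compound 2, `CCCCCCCCCCCCCCCCCNC(=O)[C@H](O)CO[C@H]1O[C@H](CO)[C@@H](O)[C@H](O)[C@H]1NC(C)=O`: in this assay compound 2 gives > 10000 nM, likewise a limit and not a number.

Within the data shown here, compound 2 therefore stands at the limit of this assay, and the one further value shown, that of compound 1, is a limit as well; the step that the two limits leave unreadable from compound 1 to compound 2 cannot be read for that reason, and the limit of > 10000 nM in this assay, at which 2 of the 2 values shown sit, is the only evidence the measured pair offers. Compound 3, `CCCCCC/C=C\CCCCCCCCNC(=O)[C@H](O)CO[C@H]1O[C@H](CO)[C@@H](O)[C@H](O)[C@H]1NC(C)=O`, is not yet measured in this assay. It differs from compound 2 by a group of 8 heavy atoms (8 carbon; no ring) in place of a group of 9 heavy atoms (9 carbon; no ring), on a saturated chain carbon, eight bonds along the chain from an amide-type nitrogen. Among the measured compounds shown here, no measured step bears directly on this change, since the one step between compounds 1 and 2 is unreadable and both values sit at the limit. With nothing on the numbers pointing to stronger inhibition, compound 3 is expected to remain at or near that limit, so the estimated step that the limit leaves unreadable from compound 2 to compound 3 would be none beyond the scatter. Compound 3 is estimated in this assay at 12000 nM, with a range from 4000 nM to 40000 nM, and most likely only a limit would again be reported.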

Compound 3, half-maximal inhibitory concentration: > 10000 nM
Compound 3: a limit, no number; the forecaster's own chance of this, stated with the estimate: 80%; the middle value does not contradict the limit.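

In this assay compound 3 gives > 10000 nM, a limit and not a number. The steps from compound 1 and compound 2 to compound 3 therefore cannot be read, and all three compounds rest at the same boundary: the limit of > 10000 nM in this assay, at which 3 of the 3 values shown sit.

The compounds shown leave open how these three chains rank, and whether any chain on the shared core gives a measurable value in this assay.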